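A few compounds are considered here, and "the series" means these few. Any claim that something is new, unique, unknown or untested is made for them only; others in the source may bear on it.

Measured compounds in this series:
- compound 1 `COc1ccc([C@@H]2CC(=O)c3c(O)cc(OCc4cn(Cc5ccccc5Cl)nn4)cc3O2)cc1O` gives 6140 nM
- compound 2 `COc1ccc([C@@H]2CC(=O)c3c(O)cc(OCc4cn(Cc5ccc(C)cc5)nn4)cc3O2)cc1O` gives 16800 nM
- compound 3 `C=CCn1cc(COc2cc(O)c3c(c2)O[C@H](c2ccc(OC)c(O)c2)CC3=O)nn1` gives 13800 nM

All three share one core and differ only in the group carried on the saturated chain carbon bound to the aromatic nitrogen of the triazole. In a functional assay on RAW264.7 cells (Mus musculus) for inhibition, read by Griess assay, with stated times of 2 h and 24 h (on this read-out higher numbers stand for weaker inhibition and lower numbers for stronger inhibition), compound 1 stands lowest of the three numbers; the two steps away from it, a 2.7-fold higher number from compound 1 to compound 2 (0.44 log units; beyond the scatter) and a 2.2-fold higher number from compound 1 to compound 3 (0.35 log units; beyond the scatter), both lie beyond the scatter, while a 1.2-fold lower number from compound 2 to compound 3 (0.09 log units; within the scatter) does not separate compound 2 from compound 3.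

Compound 4 `COc1ccc([C@@H]2CC(=O)c3c(O)cc(OCc4cn(C5CCCCC5)nn4)cc3O2)cc1O` is not yet measured. It differs from compound 1 as follows: cyclohexyl in place of 2-chlorobenzyl on an aromatic nitrogen. This is a larger departure than either measured step. The whole 2-chlorobenzyl leaves, and a non-aromatic ring, cyclohexyl, enters on the aromatic nitrogen. The two measured steps from compound 1, a 2.7-fold higher number from compound 1 to compound 2 (0.44 log units; beyond the scatter) and a 2.2-fold higher number from compound 1 to compound 3 (0.35 log units; beyond the scatter), both gave modestly higher numbers when the 2-chlorophenyl was exchanged, so a step in the same direction, of a similar modest size, is expected here: a 2.1-fold higher number from compound 1 to compound 4 (0.33 log units; beyond the scatter). Compound 4 is therefore estimated at 13000 nM in this assay, with an expected range from 5000 nM to 35000 nM.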

Compound 4, half-maximal inhibitory concentration: 15600 nM
Compound 4: middle estimate off by 1.2-fold (0.08 log units), on the low side, within the range that was stated.
By their numbers in this assay, from the lowest: compound 1; then compounds 3, 4 and 2 (each within the scatter of the next).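

In this assay the exchange of the whole 2-chlorobenzyl for cyclohexyl on the aromatic nitrogen gives a 2.5-fold higher number from compound 1 to compound 4 (0.40 log units; beyond the scatter) and so adds a non-aromatic ring to the two earlier exchanges, all of which leave compound 1 with the lowest number of the series. Cyclohexyl is not separated from allyl or from 4-methylbenzyl at this position, with a 1.1-fold higher number from compound 3 to compound 4 (0.05 log units; within the scatter) and with a 1.1-fold lower number from compound 2 to compound 4 (0.03 log units; within the scatter), so an open chain, a substituted benzyl and a non-aromatic ring all sit at one level within the scatter. Among the four groups only the 2-chlorobenzyl of compound 1 stands apart, and nothing measured here accounts for that separation.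

Going by these compounds, whether the chlorine or its place on the benzyl ring sets compound 1 apart stays open, and an unsubstituted benzyl or a 4-chlorobenzyl on the same nitrogen would bear on that question. On these data alone, how an amine, a carboxylic acid or a longer alkyl chain at this position would compare with these four groups also stays open.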